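The source may report more compounds than this note shows. Statements on the series, on what has been measured and on what is new or still open speak of the compounds shown alone.

Compound 1 `c1ccc2ncc(N3CCCNCC3)cc2c1` — in an assay on HEK293 cells for displacement of a labelled ligand from Neuronal acetylcholine receptor; alpha4/beta2 (Homo sapiens) (on this read-out higher numbers stand for weaker inhibition and lower numbers for stronger inhibition), compound 1 gives 6.61 nM
Compound 2 `Oc1cncc(N2CCCNCC2)c1` — in this assay compound 2 gives 2.4 nM
Compound 3 `Oc1cc(N2CCCNCC2)cnc1I` — in this assay compound 3 gives 21.9 nM

Among these three, compound 2 stands at the lowest number in this assay; compound 1 comes nearest with a higher value, and compound 3 lies furthest from it. Going by the values given here, the only single-point step that has been measured runs a 9.1-fold higher number from compound 2 to compound 3 (0.96 log units; beyond the scatter) and concerns a substituent on an aromatic carbon, not on the oxygen; it shows that the core of compound 2 does not accept every added group without loss, but it does not touch the hydroxy itself. Compound 4 `C=COc1cncc(N2CCCNCC2)c1` differs from compound 2 by vinyl in place of hydrogen on an oxygen on an aromatic ring. Among the compounds with values here, no measured pair tests a change at this oxygen, so the expectation rests on the general sense that additions to compound 2 have so far raised the number. A step of moderate size toward a higher number is therefore expected, a 3.3-fold higher number from compound 2 to compound 4 (0.52 log units; beyond the scatter), though a result within the scatter would not surprise. Compound 4 is accordingly estimated at 8 nM, with a likely range from 2.5 nM to 30 nM.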

Compound 4, half-maximal inhibitory concentration: 5.01 nM
Compound 4: the middle estimate sits 1.6-fold (0.20 log units) above what was measured; measured number inside the range.
By their numbers in this assay, from the lowest: compound 2; then compounds 4 and 1 (each within the scatter of the next); then compound 3.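

In this assay, going by these compounds alone, hydroxy to vinyloxy is the first measured change at this oxygen, and it gives a 2.1-fold higher number from compound 2 to compound 4 (0.32 log units; beyond the scatter). The step lies beyond the scatter, so the change is not silent, but it is modest, and without the hydrogen on this oxygen compound 4 still gives 5.01 nM. Nothing available explains why this change costs so little.

The compounds shown leave open whether the rise follows from the loss of the hydrogen or from the vinyl itself, and how a saturated ethyl group or a longer chain on the same oxygen would read. They also leave open how an amine in place of the hydroxy would compare in this assay.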